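Aryl change on the thioether arm of compound 2

A few compounds are considered here, and "the series" means these few. Any claim that something is new, unique, unknown or untested is made for them only; others in the source may bear on it.

Measured: compound 1 `O=[N+]([O-])c1ccccc1CSc1ncnc2c1ncn2[C@@H]1O[C@H](CO)[C@@H](O)[C@H]1O`, 115 nM; compound 2 `CC(C)(C)c1ccc(CSc2ncnc3c2ncn3[C@@H]2O[C@H](CO)[C@@H](O)[C@H]2O)cc1`, 10000 nM.

Compound 2 has the highest of the two numbers in an assay on isolated protein for inhibition of Equilibrative nucleoside transporter 1 (Homo sapiens); a lower number here means a stronger inhibitor, a higher number a weaker inhibitor; its nearest neighbour is compound 1, with an 87-fold higher number from compound 1 to compound 2 (1.94 log units; beyond the scatter). Compound 3 `Cc1cc(C)c(CSc2ncnc3c2ncn3[C@@H]2O[C@H](CO)[C@@H](O)[C@H]2O)c(C)c1` differs from compound 2 by 2,4,6-trimethylphenyl in place of 4-(tert-butyl)phenyl on a saturated chain carbon bound to a sulfur. Among the compounds with values here, no measured step changes the aryl group in this particular way; the only step available, an 87-fold higher number from compound 1 to compound 2 (1.94 log units; beyond the scatter), shows that the aryl group alone can move the number a long way. Compound 3 is therefore expected to come out somewhat lower, a 2.5-fold lower number from compound 2 to compound 3 (0.40 log units; beyond the scatter), with wide uncertainty. The estimate for compound 3 in this assay is 4000 nM (range 800 nM to 20000 nM).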

Compound 3, inhibition constant: 1910 nM
The estimate for compound 3 lay 2.1-fold (0.32 log units) above the measured number, and the stated range covers the measured number.
By their numbers in this assay, from the lowest: compound 1; then compound 3; then compound 2.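

In this assay, the aryl group still moves the number when both groups contain only carbon, with a 5.2-fold lower number from compound 2 to compound 3 (0.72 log units; beyond the scatter) on going to 2,4,6-trimethylphenyl. That gain recovers only part of the loss from 2-nitrophenyl, leaving a 17-fold higher number from compound 1 to compound 3 (1.22 log units; beyond the scatter). No measurement on hand accounts for either step.

Going by these compounds, it remains open whether the nitro group itself or the substitution pattern on the ring drives the gap. On these data alone, the effect in this assay of an amine or carboxylic acid on the aryl ring, or of a longer chain in place of the saturated chain carbon, also remains open.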